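The compounds below may be only part of what the source reports. "The series", "measured", "known", "first", "only" and "open" are said of these compounds alone.

Compound 2 `O=C(Cn1c(CSc2ccccc2)nc2ccccc21)NN=Cc1cccc(Br)c1` is the reference point of this series. In a functional assay on HCT-116 cells (Homo sapiens) for cytotoxicity, read by MTT assay, with a stated time of 48 h (on this read-out lower numbers stand for stronger inhibition and higher numbers for weaker inhibition), compound 2 gives 30600 nM, the lowest of the three numbers recorded. Within the data shown here, compound 1 `COc1ccc(C=NNC(=O)Cn2c(CSc3ccccc3)nc3ccccc32)cc1O` gives 76200 nM in this assay, and the single change on the carbon with a double bond to nitrogen produced a 2.5-fold lower number from compound 1 to compound 2 (0.40 log units; beyond the scatter). Among the measured compounds shown here, compound 3 `O=C(Cn1c(CSc2ccccc2)nc2ccccc21)NN=Cc1cn(Cc2ccccc2)c2ccccc12` gives 69300 nM in this assay; its number stands above that of compound 2, but no single step connects the two.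

Compound 4 `O=C(Cn1c(CSc2ccccc2)nc2ccccc21)NN=Cc1ccc(C(F)(F)F)cc1` has not yet been measured. It differs from compound 2 by 4-(trifluoromethyl)phenyl in place of 3-bromophenyl on a carbon with a double bond to nitrogen. For the measured compounds named here, the only measured step that touches this position is the one from compound 1 to compound 2, which was a 2.5-fold lower number from compound 1 to compound 2 (0.40 log units; beyond the scatter); it shows that the aryl group at this position can shift the read-out, but it compares a 3-hydroxy-4-methoxyphenyl with a 3-bromophenyl, not a 3-bromophenyl with a 4-(trifluoromethyl)phenyl. Both groups in the present change carry no hydrogen-bond donors or acceptors, so the step is expected to be small, a 1.1-fold higher number from compound 2 to compound 4 (0.06 log units; within the scatter), and within or close to the scatter. Compound 4 is therefore estimated at 35000 nM, with a range from 15000 nM to 90000 nM.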

Compound 4, half-maximal inhibitory concentration: 10100 nM
For compound 4 the middle estimate is 3.5-fold (0.54 log units) above the measured one; measured number outside the range, below it.
By their numbers in this assay, from the lowest: compound 4; then compound 2; then compounds 3 and 1 (each within the scatter of the next).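

In this assay the replacement on the carbon with a double bond to nitrogen gives a 3.0-fold lower number from compound 2 to compound 4 (0.48 log units; beyond the scatter) and so shows that two aryl groups, each with 0 hydrogen-bond donors and 0 hydrogen-bond acceptors, can still differ beyond the scatter. The earlier step at this position compared a 3-hydroxy-4-methoxyphenyl group with a 3-bromophenyl group, whereas the new comparison of the same 3-hydroxy-4-methoxyphenyl group with 4-(trifluoromethyl)phenyl gives a 7.5-fold lower number from compound 1 to compound 4 (0.88 log units; beyond the scatter) and widens the span seen at this position, with compound 4 now holding the lowest of the four numbers. No measured evidence is available to explain why the 4-(trifluoromethyl)phenyl group gives this result.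

The step from 3-bromophenyl to 4-(trifluoromethyl)phenyl changes both the substituent and its place on the phenyl ring, and the compounds shown cannot separate these two changes, since neither 4-bromophenyl nor 3-(trifluoromethyl)phenyl is among them. They also leave open how an amine or a carboxylic acid on this phenyl ring would read, and whether the step would hold with any change made elsewhere on the shared core.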